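Ester-to-acid step on the cyclopropyl-amino purine series

A few compounds are considered here, and "the series" means these few. Any claim that something is new, unique, unknown or untested is made for them only; others in the source may bear on it.

Measured so far in a functional assay on the whole organism (Tail, strain ICR) with Mus musculus as the target, in the tail flick test, with a stated time of 30 min, at a dose of 25 umol/kg by the oral route; a higher number here means a stronger effect of the compound at the dose given, a lower number a weaker effect:
compound 1 `CC(C)[C@H](NC(=O)CN(c1nc(Cl)nc2[nH]cnc12)C1CC1)C(=O)OCc1ccccc1`: 33.4%
compound 2 `C[C@@H](O)[C@H](NC(=O)CN(c1nc(Cl)nc2[nH]cnc12)C1CC1)C(=O)OCc1ccccc1`: 21.9%
compound 3 `N=C(N)NCCC[C@H](NC(=O)CN(c1nc(Cl)nc2[nH]cnc12)C1CC1)C(=O)OCc1ccccc1`: 23.2%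

Compound 1 stands highest of the three numbers. The two steps away from it both run downward and both lie beyond the scatter: a number 11.5 percentage points lower from compound 1 to compound 2 (beyond the scatter), and a number 10.2 percentage points lower from compound 1 to compound 3 (beyond the scatter). Between the other two there is no real gap: a number 1.3 percentage points higher from compound 2 to compound 3 (within the scatter).

Compound 4 `CC(C)[C@H](NC(=O)CN(c1nc(Cl)nc2[nH]cnc12)C1CC1)C(=O)O` is the next compound to be measured. Its difference from compound 1 is hydrogen in place of benzyl on an oxygen next to a carbonyl group — read one bond further out, benzyloxycarbonyl to carboxy. All three measured steps vary the group on the saturated chain carbon bound to an amide-type nitrogen and a carbonyl carbon; none touches the oxygen next to the carbonyl group, so none bears directly on this step. What the measured steps do show is that changes at a single site in this series move the number by modest amounts, and that the three numbers sit within a narrow band.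

Within the data shown here, with no step at this place to lean on, the expectation for compound 4 is a value in or somewhat below that band, with a wide range: estimated at 22% (range 5% to 40%), which would mean an expected step of a number 11.4 percentage points lower from compound 1 to compound 4 (beyond the scatter).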

Compound 4, a percentage reported as activity, at one dose (the size of the read-out at that dose, not a potency): 31.2%
Compound 4: the middle estimate sits 9.2 percentage points below what was measured; the measured number falls inside the stated range.
By their numbers in this assay, from the lowest: compounds 2, 3, 4 and 1 (each within the scatter of the next, the first and the last beyond it).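

In this assay, hydrogen in place of benzyl on an oxygen next to a carbonyl group gives a number 2.2 percentage points lower from compound 1 to compound 4 (within the scatter), so on the compound with the isopropyl group, benzyloxycarbonyl and carboxy cannot be told apart at this dose and time. Among these compounds, this is the first reading at this oxygen, as the earlier steps all varied the group on the saturated chain carbon, and it shows that the benzyl group, with its six-membered aromatic ring, is not required for a number of this size in this test. Nothing at hand explains why the two compounds read alike.

The compounds shown leave open whether the same change reads the same way on the 1-hydroxyethyl chain of compound 2 or on the longer nitrogen-bearing chain of compound 3, where the benzyl group is still in place. Also open, on these data alone, is how a methyl ester or a primary amide would read in place of the benzyloxycarbonyl or carboxy group, and whether the match between compound 1 and compound 4 holds at other doses or times.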